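Replacing the isopropyl group of compound 3

The source may hold more compounds than are shown below. What is called first, only, known or untested is meant among the compounds shown, and "the series" means these compounds.

In an ADME assay on microsomes from liver (Homo sapiens) for metabolic stability, read by LC-MS, with a stated time of 10 min (a lower number here means that less of the compound is left, a higher number that more of the compound is left), compound 1 (`C[C@@H]1CN(c2cccc3c2C[C@H](CN(C)[C@H]2CCCc4cccnc42)NC3)C[C@H](C)N1`) gives 100% and compound 2 (`CN(C[C@H]1Cc2c(cccc2N2CCNC(C)(C)C2)CN1)[C@H]1CCCc2cccnc21`) gives 100%. Compound 3 (`CC(C)N1CCN(c2cccc3c2C[C@H](CN(C)[C@H]2CCCc4cccnc42)NC3)CC1`) stands lowest of the three at 56.6%. Compound 4 (`CN(C[C@H]1Cc2c(cccc2N2CCN(c3cccc(C(F)(F)F)c3)CC2)CN1)[C@H]1CCCc2cccnc21`) carries 3-(trifluoromethyl)phenyl in place of isopropyl on an amine nitrogen in a ring. The nearest measured evidence is a number 43.4 percentage points lower from compound 1 to compound 3 (beyond the scatter) and a number 43.4 percentage points lower from compound 2 to compound 3 (beyond the scatter), both large, whereas no change at the digits printed from compound 1 to compound 2 (within the scatter) stays within the scatter. None of these steps brings in an aromatic group, so they show that the number can move widely but give no firm direction. The expected change is a number 6.6 percentage points lower from compound 3 to compound 4 (within the scatter), which would stay within the scatter. Compound 4 is estimated at 50%, with an expected range of 20% to 85%.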

Compound 4, percent of the compound remaining: 90.3%
The estimate for compound 4 lay 40.3 percentage points below the measured number; the whole stated range lies below it.
By their numbers in this assay, from the lowest: compound 3; then compounds 4, 1 and 2 (each within the scatter of the next).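

In this assay, the change from isopropyl to 3-(trifluoromethyl)phenyl on the ring amine nitrogen gives a number 33.7 percentage points higher from compound 3 to compound 4 (beyond the scatter) as its result, so this nitrogen can carry an aromatic group of far more heavy atoms without the number staying low. The low value of compound 3 is therefore not shared by every substituent on this nitrogen. Nothing available explains the rise.

As far as these compounds go, it remains open whether an unsubstituted phenyl, a pyridine ring or an acetyl group on this nitrogen would match compound 3 or compound 4. From the compounds shown here alone, the part played by the trifluoromethyl group itself also stays open.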